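Bromo to Nitro at the Cytotoxicity Limit

The source may hold more compounds than are shown below. What is called first, only, known or untested is meant among the compounds shown, and "the series" means these compounds.

Three compounds share one core. Compound 1 `CCOC(=O)CCCCCOc1cccc(CN(C(=O)c2ccc(-c3cc(OC)cc(OC)c3)cc2)C(C)C)c1` carries a 3,5-dimethoxyphenyl; in an ADME assay on HEK293 cells (Homo sapiens) for cytotoxicity, read by CellTiter-Glo and resazurin assay, with a stated time of 72 h (a higher number here means that more compound is needed for the effect, a lower number that less compound is needed), compound 1 gives only a limit of the assay, > 26000 nM. Compound 2 `CCOC(=O)CCCCCOc1cccc(CN(C(=O)c2ccc(-c3cccc(O)c3)cc2)C(C)C)c1` carries a 3-hydroxyphenyl instead; in this assay compound 2 likewise gives only a limit, > 26000 nM. Compound 3 `CCOC(=O)CCCCCOc1cccc(CN(C(=O)c2ccc(-c3cccc(Br)c3)cc2)C(C)C)c1` carries a 3-bromophenyl; in this assay compound 3 also gives only a limit, > 26000 nM. Because of the limit of > 26000 nM in this assay, at which 3 of the 3 values shown sit, none of the steps between these compounds can be read: a step that the two limits leave unreadable from compound 1 to compound 2, a step that the two limits leave unreadable from compound 1 to compound 3 and a step that the two limits leave unreadable from compound 2 to compound 3. So compound 3 stands where every measured compound stands, at the limit, with no ordering among them.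

Compound 4 `CCOC(=O)CCCCCOc1cccc(CN(C(=O)c2ccc(-c3cccc([N+](=O)[O-])c3)cc2)C(C)C)c1` differs from compound 3 by nitro in place of bromo on an aromatic carbon. All three measured steps bear on this change only in that none showed an effect readable within the assay. For the measured compounds named here, no step gives a direction or a size, so compound 4 is expected to remain at the limit as well. This amounts to an expected a number no higher from compound 3 to compound 4 (the limit leaves the size open). Compound 4 is estimated at 26000 nM in this assay, within 10000 nM to 80000 nM.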

Compound 4, half-maximal effective concentration: > 26000 nM
Compound 4 ended at the assay's limit (the forecaster's own chance of this, stated with the estimate: 85%); the middle value sits exactly at the limit.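

In this assay compound 4 also gives only a limit, > 26000 nM. Its steps to compound 1, compound 2 and compound 3 cannot be read: the limit of > 26000 nM in this assay, at which 4 of the 4 values shown sit.

The compounds shown leave open whether these four differ at all in this assay, and at what concentration any of them would reach a half-maximal effect.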